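Pyrrolidinyl for furanyl on two related fused cores

A few compounds are considered here, and "the series" means these few. Any claim that something is new, unique, unknown or untested is made for them only; others in the source may bear on it.

Compound 1 `Cc1cc(-c2ccoc2)cn2c(CSCCc3ccccc3)cnc12` and compound 3 `Cc1cc(-c2ccoc2)c2ncc(CSCCc3ccccc3)n2c1` are built from the same atoms joined differently; the difference between the two cores is not broken down here. In an ADME assay on HEL cells (Homo sapiens) for cytotoxicity, with a stated time of 3 days (on this read-out higher numbers stand for lower toxicity in this test and lower numbers for higher toxicity in this test), compound 1 gives only a limit of the assay, > 4 ug/mL. In this assay compound 2 `Cc1cc(N2CCCC2)cn2c(CSCCc3ccccc3)cnc12` gives 20 ug/mL. In this assay compound 3 gives 100 ug/mL, the highest of the two numbers and beyond the scatter from compound 2. The change pyrrolidin-1-yl in place of furan-3-yl on an aromatic carbon made a step that the limit leaves unreadable from compound 1 to compound 2, since (the limit of > 4 ug/mL in this assay, at which 1 of the 3 values shown sits). Compound 4 `Cc1cc(N2CCCC2)c2ncc(CSCCc3ccccc3)n2c1` is not yet measured and carries the same kind of change, (pyrrolidin-1-yl in place of furan-3-yl on an aromatic carbon), ortho to a fused ring where in compound 2 the group sits para to a fused ring. The expected step is a 1.7-fold lower number from compound 3 to compound 4 (0.22 log units; within the scatter), resting on compound 2 at 20 ug/mL. Compound 4 is estimated at 60 ug/mL, between 15 ug/mL and 200 ug/mL.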

Compound 4, minimum cytotoxic concentration: > 100 ug/mL
Compound 4: only a limit was reported (the forecaster's own chance of this, stated with the estimate: 20%); at least 1.6-fold (0.22 log units) between middle value and limit.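

In this assay, the change to pyrrolidin-1-yl in place of furan-3-yl on an aromatic carbon gave a number no lower from compound 3 to compound 4 (the limit leaves the size open), so on this core the number did not fall. Compound 4 gives only a limit of the assay, > 100 ug/mL, and the size of the step stays unread because of it: the limit of > 100 ug/mL in this assay, at which 1 of the 4 values shown sits. The step from compound 1 to compound 2 cannot be read either, so the series does not show whether the change has the same size on both cores: the limit of > 4 ug/mL in this assay, at which 1 of the 4 values shown sits.

The compounds shown leave open how the number would move on either core with another group at this place, such as morpholin-4-yl or a carboxylic acid.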